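Sulfone for gem-dimethylcyclohexyl on the pyrazole nitrogen

The compounds below may be only part of what the source reports. "The series", "measured", "known", "first", "only" and "open" are said of these compounds alone.

Measured so far:
compound 1, `O=C(Cn1nnc(-c2ccccc2)n1)NC1CC2CCC1C2`, 13%
compound 2, `Cc1cc(NC(=O)Cn2nnc(-c3ccccc3)n2)n(C2CCC(C)(C)CC2)n1`, > 19%

Two compounds share the phenyltetrazole acetamide arm and have been run in an assay on HEK293 cells for activation of Kir3.1/Kir3.2 (Homo sapiens), read by thallium flux; on this read-out lower numbers stand for smaller maximal responses and higher numbers for larger maximal responses. Compound 1, `O=C(Cn1nnc(-c2ccccc2)n1)NC1CC2CCC1C2`, with a bicyclic amine on the amide, gives 13%. Compound 2, `Cc1cc(NC(=O)Cn2nnc(-c3ccccc3)n2)n(C2CCC(C)(C)CC2)n1`, is reported only as a limit of the assay, > 19%, so its true maximal response is not known as a number. This is recorded as the limit of > 19% in this assay, at which 1 of the 2 values shown sits, a limit at which one of the two values shown sits. Among the measured compounds shown here, no step between two fully measured compounds is available, so no comparison of sizes can be drawn from the data themselves.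

Compound 3, `Cc1cc(NC(=O)Cn2nnc(-c3ccccc3)n2)n(C2CCS(=O)(=O)CC2)n1`, is the next compound to be tested in this assay. It differs from compound 2 in one place: 1,1-dioxothian-4-yl in place of 4,4-dimethylcyclohexyl on an aromatic nitrogen. Since compound 2 stands at a limit, the step from compound 2 to compound 3 in this assay cannot be anchored to a fixed starting value; a change beyond the usual scatter in either direction is possible, and none beyond the scatter is equally plausible. Compound 3 is expected to give about 25%, in a range from 10% to 45%, which would mean an estimated step that the limit leaves unreadable from compound 2 to compound 3.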

Compound 3, largest response reached (Emax), in percent of the reference or control that the assay uses: > 25%
Compound 3: no number, only a limit (the forecaster's own chance of this, stated with the estimate: 30%); the middle value lies on the limit itself.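

In this assay compound 3 gives > 25%, a limit of the assay and not a number. Among the compounds shown here, compound 2 is also reported as a limit, > 19%, and no step from compound 2 to compound 3 can be read. The compounds shown leave open how large either maximal response is, and whether 1,1-dioxothian-4-yl in place of 4,4-dimethylcyclohexyl changes it at all.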